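Hydroxyalkyl amide variation in a lipopeptide-type series

This account rests on a few compounds, and the source may have more. Where it says the series, first, only, none or still open, it means among the compounds named here.

Measured compounds:
compound 1, `CCCCCCCCCCCC(=O)OC[C@H](CSC[C@@H](N)C(=O)NCCO)OC(=O)CCCCCCCCCCC`, 24 nM
compound 2, `CCCCCCCCCCCC(=O)OC[C@H](CSC[C@@H](N)C(=O)NCCCCCCO)OC(=O)CCCCCCCCCCC`, 33 nM

Both measured compounds share one core and differ only in the group on the amide-type nitrogen. In an assay on HEK293 cells for agonist activity at Toll-like receptor 2 (Homo sapiens) (on this read-out lower numbers stand for an effect already at smaller amounts and higher numbers for an effect only at larger amounts of compound), compound 1 gives 24 nM and compound 2 gives 33 nM. Compound 2 thus carries the higher of the two numbers, but the gap to compound 1, a 1.4-fold higher number from compound 1 to compound 2 (0.14 log units; within the scatter), stays within the scatter, so the two cannot be ordered.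

Compound 3, `CCCCCCCCCCCC(=O)OC[C@H](CSC[C@@H](N)C(=O)NC1(CO)CC1)OC(=O)CCCCCCCCCCC`, has not yet been measured. It differs from compound 2 in one place: 1-(hydroxymethyl)cyclopropyl in place of 6-hydroxyhexyl on an amide-type nitrogen. For the measured compounds named here, the only step that bears on this position is a 1.4-fold higher number from compound 1 to compound 2 (0.14 log units; within the scatter), and it was within the scatter. Going by the values given here, that step, however, exchanged one open-chain hydroxyalkyl group for another; the ring entering in compound 3 has no counterpart among the measured compounds, so the prior evidence is thin.

In this assay, compound 3 is expected to give 40 nM, with a range of 12 nM to 130 nM. The expected step, a 1.2-fold higher number from compound 2 to compound 3 (0.08 log units; within the scatter), is estimated to be small, in either direction, with the range widened for the untested ring.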

Compound 3, half-maximal effective concentration: 265 nM
For compound 3 the middle estimate is 6.6-fold (0.82 log units) below the measured one; measured number above the stated range.
By their numbers in this assay, from the lowest: compounds 1 and 2 (each within the scatter of the next); then compound 3.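

In this assay, the group on the amide-type nitrogen is not free to vary: an 8.0-fold higher number from compound 2 to compound 3 (0.90 log units; beyond the scatter), and an 11-fold higher number from compound 1 to compound 3 (1.04 log units; beyond the scatter). The earlier pair showed only that 2-hydroxyethyl and 6-hydroxyhexyl could not be told apart, whereas compound 3 shows that a hydroxy-bearing group on this nitrogen is not enough to keep the number near those of compound 1 and compound 2, even with the same counted hydrogen-bond donor and acceptor as 6-hydroxyhexyl. No supporting measurement accompanies these numbers, so the shift remains an observation with no established explanation.

The compounds shown leave open whether the shift goes with the three-membered ring itself or with the branching of the group, a question that an open-chain 2-hydroxy-1,1-dimethylethyl group on the same nitrogen could help separate. They also leave open whether the hydroxy group matters within the ring-bearing series, which a plain cyclopropyl or a 1-(aminomethyl)cyclopropyl group at this position would test.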